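The compounds below may be only part of what the source reports. "The series", "measured", "known", "first", "only" and "open" are said of these compounds alone.

Compound 1 `COc1cc(-c2cc(/C=C/C(=O)c3ccc(Cl)c(Cl)c3)[nH]n2)cc(OC)c1OC`: 9830 nM
Compound 2 `COc1ccc(-c2cc(/C=C/C(=O)c3ccc(N)cc3)[nH]n2)cc1OC`: 4360 nM

Both compounds were tested in a functional assay on SNB-19 cells (Homo sapiens) for inhibition, read by sulforhodamine B assay, with a stated time of 48 h; on this read-out higher numbers stand for weaker inhibition of growth and lower numbers for stronger inhibition of growth. In this assay compound 1 gives 9830 nM, the higher of the two numbers, while compound 2 gives 4360 nM; the gap between them lies beyond the usual scatter, so compound 2 is the stronger inhibitor of growth of this pair. The two structures differ in more than one place, so their values alone cannot be tied to any single change.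

Compound 3 `COc1cc(-c2cc(/C=C/C(=O)c3ccc(F)c(F)c3)[nH]n2)cc(OC)c1OC` has not yet been measured. It differs from compound 1 in one place: 3,4-difluorophenyl in place of 3,4-dichlorophenyl on a carbonyl carbon. Going by the values given here, no measured pair shows what this exchange does in this assay. With no such comparison at hand, the expected step is a 1.2-fold higher number from compound 1 to compound 3 (0.09 log units; within the scatter), meant as none beyond the scatter in either direction. Compound 3 is therefore estimated to give about 12000 nM, within a range from 5000 nM to 30000 nM.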

Compound 3, concentration for 50% growth inhibition: 3640 nM
Compound 3: middle estimate off by 3.3-fold (0.52 log units), on the high side; measured number outside the range, below it.
By their numbers in this assay, from the lowest: compounds 3 and 2 (each within the scatter of the next); then compound 1.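

Changing only the two halogens on this ring, from 3,4-dichlorophenyl to 3,4-difluorophenyl on the carbonyl carbon, gives a 2.7-fold lower number from compound 1 to compound 3 (0.43 log units; beyond the scatter) in this assay. Going by these compounds alone, this is the first comparison here that ties a difference in growth inhibition to one structural change, and it shows that this position responds to the identity of the halogen, even though the two groups match in heavy-atom count and ring type. Nothing available here explains why the exchange has this effect.

A single pair cannot show whether the trend continues beyond these two halogens. Going by these compounds, the effect of an unsubstituted phenyl, a 3,4-dimethoxyphenyl or a 3,4-dibromophenyl at this same place, with the rest of compound 3 kept unchanged, remains open.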